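Aryl exchange on the sulfonyl sulfur: compound 2 to compound 3

This account rests on a few compounds, and the source may have more. Where it says the series, first, only, none or still open, it means among the compounds named here.

Compound 1 `CC1CCN(C2CCN(S(=O)(=O)c3ccc(C#N)cc3)CC2)CC1` gives 2800 nM in a functional assay on DLD-1 cells (Homo sapiens) for antiproliferative activity, read by CellTiter-Glo, with a stated time of 72 h; on this read-out lower numbers stand for stronger inhibition and higher numbers for weaker inhibition. Compound 2 `CC1CCN(C2CCN(S(=O)(=O)c3ccc(Cl)nc3)CC2)CC1` gives 3700 nM in this assay, the higher of the two numbers shown so far, although the only step leading to it, a 1.3-fold higher number from compound 1 to compound 2 (0.12 log units; within the scatter), is within the scatter. Compound 3 `CC1CCN(C2CCN(S(=O)(=O)c3cccc(Br)c3)CC2)CC1` has not yet been measured in this assay. It differs from compound 2 at one place only: 3-bromophenyl in place of 6-chloropyridin-3-yl on a sulfonyl sulfur. For the measured compounds named here, the single measured step that bears on this change, a 1.3-fold higher number from compound 1 to compound 2 (0.12 log units; within the scatter), also exchanged the aromatic group on the sulfonyl sulfur and moved the number by less than the scatter; no other comparison is available. The expected step is accordingly a 1.2-fold lower number from compound 2 to compound 3 (0.06 log units; within the scatter), that is, no change beyond the scatter. Compound 3 is estimated at 3200 nM in this assay, with a range of 1200 nM to 8500 nM.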

Compound 3, half-maximal inhibitory concentration: 3.2 nM
Compound 3: middle estimate off by 1000-fold (3.00 log units), on the high side; measured number outside the range, below it.
By their numbers in this assay, from the lowest: compound 3; then compounds 1 and 2 (each within the scatter of the next).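

Exchange of the aromatic group on the sulfonyl sulfur is not generally neutral in this assay: the change from 4-cyanophenyl to 6-chloropyridin-3-yl stayed within the scatter, yet 3-bromophenyl gives a 1200-fold lower number from compound 2 to compound 3 (3.06 log units; beyond the scatter) and an 880-fold lower number from compound 1 to compound 3 (2.94 log units; beyond the scatter) on the same core. Of the three aromatic groups shown, only 3-bromophenyl stands apart, so this position can carry a very large difference, and the two earlier compounds gave no sign of it. No measurement bears on the origin of this difference.

Open, on these data alone, is whether the bromine itself, its place on the ring or the carbon-only ring accounts for the step. Phenyl without a substituent, 3-chlorophenyl and 4-bromophenyl on the same sulfonyl sulfur would separate these readings.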